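Oxazole piperidine amides: permeability notes on the series

The source may hold more compounds than are shown below. What is called first, only, known or untested is meant among the compounds shown, and "the series" means these compounds.

Measured compounds:
compound 1 `Cc1ccc(C)c(-c2nc(CN3CCC(C(=O)NCCCN4C[C@H](C)C[C@H](C)C4)CC3)c(C)o2)c1` — a physicochemical assay for permeability, using PAMPA; a lower number here means that the compound crosses the layer more slowly, a higher number that the compound crosses the layer faster: "not determined" (no result reported)
compound 2 `Cc1ccccc1-c1nc(CN2CCC(C(=O)NCCCN3CCC(C)(C)CC3)CC2)c(C)o1` — 241 10^-6 cm/s
compound 3 `Cc1ccccc1-c1nc(CN2CCC(C(=O)N3CCN(C4CCN(C)CC4)CC3)CC2)c(C)o1` — < 3.2 10^-6 cm/s, a limit of the assay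

Compound 1 has no number in this assay; its entry reads "not determined" (no result reported). Compound 2 gives 241 10^-6 cm/s in this assay. Compound 3 gives < 3.2 10^-6 cm/s, which is a limit of the assay and not a number; (the limit of < 3.2 10^-6 cm/s in this assay, at which 1 of the 3 values shown sits). Compound 4 `Cc1cccc(F)c1-c1nc(CN2CCC(C(=O)NCCCN3C[C@H](C)C[C@H](C)C3)CC2)c(C)o1` differs from compound 1 by 2-fluoro-6-methylphenyl in place of 2,5-dimethylphenyl on an aromatic carbon. Among the measured compounds shown here, no measured pair shows this change, so in this assay no step beyond the usual scatter is expected from it, in either direction. The expectation for compound 4 rests on compound 2, which gives 241 10^-6 cm/s. Compound 4 is expected to give 200 10^-6 cm/s, with a range of 80 10^-6 cm/s to 400 10^-6 cm/s.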

Compound 4, apparent permeability: 234 10^-6 cm/s
The estimate for compound 4 lay 1.2-fold (0.07 log units) below the measured number; the range from low to high includes it.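

In this assay, among the compounds shown here, no step from compound 1 to compound 4 can be read. The compounds shown leave open how 2-fluoro-6-methylphenyl compares with 2,5-dimethylphenyl on the shared core, and nothing shown bears on the result for compound 4.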